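The source may report more compounds than this note shows. Statements on the series, on what has been measured and on what is new or still open speak of the compounds shown alone.

Measured compounds:

Compound 1, `O=C(Nc1ccc(Cl)c(-c2nnc3c(Cl)cccn23)c1)c1ccc(F)cc1Cl`: > 100000 nM
Compound 2, `O=C(Nc1ccc(Cl)c(-c2nnc3c(Cl)cccn23)c1)c1ccc(Cl)cc1`: > 100000 nM
Compound 3, `O=C(Nc1ccc(Cl)c(-c2nnc3c(Cl)cccn23)c1)c1cccnc1Cl`: 87500 nM

All three share one core and differ only in the group on the carbonyl carbon of the amide. In a functional assay on HeLa cells (Homo sapiens) for antiproliferative activity, read by MTT assay, with a stated time of 72 h (on this read-out higher numbers stand for weaker inhibition and lower numbers for stronger inhibition), compound 2 gives > 100000 nM, which is a limit of the assay and not a number. Compound 1 likewise gives a limit in this assay, > 100000 nM. Compound 3, with 2-chloropyridin-3-yl on the carbonyl carbon, is the only one of the three with a measured number, 87500 nM, and the step of an at least 1.1-fold lower number from compound 2 to compound 3 (0.05 log units; that floor lies within the scatter) is a floor that lies within the scatter; the step that the two limits leave unreadable from compound 1 to compound 2 is not readable. Compound 2 therefore stands at the limit (the limit of > 100000 nM in this assay, at which 2 of the 3 values shown sit), alongside compound 1.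

Compound 4, `CS(=O)(=O)c1cccc(C(=O)Nc2ccc(Cl)c(-c3nnc4c(Cl)cccn34)c2)c1`, is not yet measured. It differs from compound 2 by 3-(methylsulfonyl)phenyl in place of 4-chlorophenyl on a carbonyl carbon. Among the compounds with values here, no measured step here involves such a group, so nothing in these three compounds indicates the direction or size of the change. The estimated step of a number no higher from compound 2 to compound 4 (the limit leaves the size open) is expected to stay within the scatter. Compound 4 is expected to give 100000 nM, between 25000 nM and 300000 nM, most likely again as a limit.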

Compound 4, half-maximal inhibitory concentration: 86400 nM
Beside the measured number, compound 4's estimate is 1.2-fold (0.06 log units) above it; the measured number falls inside the stated range.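

In this assay, compound 4 gives this position on the carbonyl carbon a second measured number, so that 3-(methylsulfonyl)phenyl can be read directly against the 2-chloropyridin-3-yl group of compound 3, and the step of a 1.0-fold lower number from compound 3 to compound 4 (0.01 log units; within the scatter) shows these two quite different groups giving the same result. Against the other two groups only floors can be read, an at least 1.1-fold lower number from compound 2 to compound 4 (0.06 log units; that floor lies within the scatter) and an at least 1.1-fold lower number from compound 1 to compound 4 (0.06 log units; that floor lies within the scatter), so the size of these changes stays unknown. Compound 2 remains at a limit of the assay, as does compound 1: the limit of > 100000 nM in this assay, at which 2 of the 4 values shown sit.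

No group shown here yet gives a step that is readably beyond the scatter. On these data alone, whether a carboxylic acid or an amine on the phenyl ring, or a longer chain in place of that ring, would do so remains open.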